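Removing a methoxy from the dimethoxyphenyl arm: compound 4

A few compounds are considered here, and "the series" means these few. Any claim that something is new, unique, unknown or untested is made for them only; others in the source may bear on it.

Measured compounds in a functional assay on UACC-257 cells (Homo sapiens) for inhibition, read by sulforhodamine B assay, with a stated time of 48 h; a lower number here means a stronger inhibitor of growth, a higher number a weaker inhibitor of growth:
Compound 1, `COc1cc(CNc2nc3cc(N)cc(N)c3nc2-c2ccccc2)cc(OC)c1OC`, gives 3470 nM.
Compound 2, `CCOC(=O)[C@H](CCC(=O)O)NC(=O)c1ccc(Oc2nc3cc(N)cc(N)c3nc2-c2ccccc2)cc1`, gives 26900 nM.
Compound 3, `COc1ccc(CNc2nc3cc(N)cc(N)c3nc2-c2ccccc2)cc1OC`, gives 12900 nM.

Compound 3 stands second highest of the three numbers; compound 2 sits above it and compound 1 below it. The unmeasured compound 4, `COc1ccc(CNc2nc3cc(N)cc(N)c3nc2-c2ccccc2)cc1`, differs from compound 3 by hydrogen in place of methoxy on an aromatic carbon.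

Among the measured compounds shown here, one measured step bears directly on this change: a 3.7-fold higher number from compound 1 to compound 3 (0.57 log units; beyond the scatter), the same loss of a methoxy on an aromatic carbon. A similar, modest rise in the number is therefore expected for compound 4, about a 2.0-fold higher number from compound 3 to compound 4 (0.30 log units; within the scatter). Compound 4 is accordingly estimated at 26000 nM, with a range from 9000 nM to 75000 nM.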

Compound 4, concentration for 50% growth inhibition: 16200 nM
Estimate against measurement, compound 4: 1.6-fold (0.21 log units) above; measured number inside the range.
By their numbers in this assay, from the lowest: compound 1; then compounds 3, 4 and 2 (each within the scatter of the next, the first and the last beyond it).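

In this assay, hydrogen in place of methoxy at this position gives a 1.3-fold higher number from compound 3 to compound 4 (0.10 log units; within the scatter), so going from 3,4-dimethoxyphenyl to 4-methoxyphenyl stays within the scatter. The same replacement at another place on the arm gave a 3.7-fold higher number from compound 1 to compound 3 (0.57 log units; beyond the scatter), so across these two steps the change does not carry one size at every place. Nothing at hand accounts for the difference between the two steps. Still open, as far as these compounds go, is whether the methoxy remaining in compound 4 matters, and whether an amine or a carboxylic acid at the vacated position would give a step beyond the scatter.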